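A few compounds are considered here, and "the series" means these few. Any claim that something is new, unique, unknown or untested is made for them only; others in the source may bear on it.

Compound 1 (`Cc1cc(C)cc(NS(=O)(=O)c2ccc(N3CCNC3=O)cc2)c1`), compound 2 (`Cc1ccc(C)c(NS(=O)(=O)c2ccc(N3CCNC3=O)cc2)c1`) and compound 3 (`O=C1NCCN1c1ccc(S(=O)(=O)Nc2cccc(Cl)c2)cc1`) share one core and differ only in the group on a sulfonamide nitrogen. In a functional assay on HT-29 cells (Homo sapiens) for antiproliferative activity, read by sulforhodamine B assay, with a stated time of 48 h (on this read-out higher numbers stand for weaker inhibition and lower numbers for stronger inhibition), compound 1 gives 82 nM and compound 2 gives 46 nM, while compound 3 gives 55 nM on the same read-out. Compound 3 therefore cannot be told apart from either of the other two.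

Compound 4 (`Cc1ccccc1NS(=O)(=O)c1ccc(N2CCNC2=O)cc1`), not yet measured, carries 2-methylphenyl in place of 3-chlorophenyl on a sulfonamide nitrogen. Three measured swaps at that same place bear on this change (a 1.8-fold lower number from compound 1 to compound 2 (0.25 log units; within the scatter); a 1.5-fold lower number from compound 1 to compound 3 (0.17 log units; within the scatter); a 1.2-fold higher number from compound 2 to compound 3 (0.08 log units; within the scatter)). None of them moved the number beyond the scatter, so no step beyond the scatter, in either direction, is expected in this assay for this swap. The estimated step is therefore small (a 1.1-fold higher number from compound 3 to compound 4 (0.04 log units; within the scatter)). For compound 4 the estimated value is 60 nM (expected range 25 nM to 140 nM).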

Compound 4, half-maximal inhibitory concentration: 200 nM
Estimate against measurement, compound 4: 3.3-fold (0.52 log units) below, outside the stated range (above it).
By their numbers in this assay, from the lowest: compounds 2, 3 and 1 (each within the scatter of the next); then compound 4.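

In this assay the group on the sulfonamide nitrogen proves able to move the number beyond the scatter, which none of the earlier swaps at this place did. Compound 4 is the weakest of the four, with a step from each of the others: a 3.6-fold higher number from compound 3 to compound 4 (0.56 log units; beyond the scatter), a 2.4-fold higher number from compound 1 to compound 4 (0.39 log units; beyond the scatter) and a 4.3-fold higher number from compound 2 to compound 4 (0.64 log units; beyond the scatter). The last of these steps is only hydrogen in place of methyl on an aromatic carbon, so even that small change matters here, though all three steps are modest in size.

Nothing available here gives a reason for the weaker inhibition of compound 4. From the compounds shown here alone, it also remains open how an amine or a carboxylic acid on the phenyl ring, in place of the methyl, would behave in this assay.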